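A fluorine for a methyl on the sulfonyl ring

The source may hold more compounds than are shown below. What is called first, only, known or untested is meant among the compounds shown, and "the series" means these compounds.

Compound 1, `COc1cc(N(Cc2ccc(F)cc2)S(=O)(=O)c2ccc(C)cc2)cc(OC)c1OC`: 19200 nM
Compound 2, `COc1cc(N(Cc2ccc(Br)cc2)S(=O)(=O)c2ccc(C)cc2)cc(OC)c1OC`: 10900 nM
Compound 3, `COc1cc(N(Cc2nc3ccccc3[nH]2)S(=O)(=O)c2ccc(C)cc2)cc(OC)c1OC`: 5400 nM

In a functional assay on MCF7 cells (Homo sapiens) for inhibition, read by MTT assay, with a stated time of 48 h (a lower number here means a stronger inhibitor, a higher number a weaker inhibitor), compound 3 stands at the lowest number of the three. The two steps leading to it, a 3.6-fold lower number from compound 1 to compound 3 (0.55 log units; beyond the scatter) and a 2.0-fold lower number from compound 2 to compound 3 (0.31 log units; beyond the scatter), are both beyond the scatter, while a 1.8-fold lower number from compound 1 to compound 2 (0.25 log units; within the scatter) is within it. Compound 4, `COc1cc(N(Cc2nc3ccccc3[nH]2)S(=O)(=O)c2ccc(F)cc2)cc(OC)c1OC`, differs from compound 3 in one place: fluoro in place of methyl on an aromatic carbon. Going by the values given here, none of the measured steps bears on this ring; all three alter the group on the chain carbon bound to the sulfonamide nitrogen. With nothing measured to guide it, the step of no change at the digits printed from compound 3 to compound 4 (within the scatter) is expected to be none beyond the scatter. Compound 4 is therefore estimated at 5400 nM, with a range from 2000 nM to 15000 nM.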

Compound 4, half-maximal inhibitory concentration: 9380 nM
Compound 4: middle estimate off by 1.7-fold (0.24 log units), on the low side, and the stated range covers the measured number.
By their numbers in this assay, from the lowest: compounds 3, 4, 2 and 1 (each within the scatter of the next, the first and the last beyond it).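

Going by these compounds alone, this is the first measured step on the sulfonyl ring, on an aromatic carbon para to a large group: with the 1H-benzimidazol-2-yl group held fixed, a 1.7-fold higher number from compound 3 to compound 4 (0.24 log units; within the scatter) stays within the scatter, so this assay does not separate 4-methylphenyl from 4-fluorophenyl here. The earlier compounds shown here changed only the group on the chain carbon, and this step shows that a change on the other ring can also leave the number within the scatter. Nothing available explains this result. From the compounds shown here alone, whether an amine or a carboxylic acid on this aromatic carbon would shift the number beyond the scatter remains open. Also open, going by these compounds, is whether fluoro in place of methyl behaves the same way when 4-bromophenyl or 4-fluorophenyl stands on the chain carbon.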